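Cyclohexyl to pentan-3-yl at the ring amine

The compounds below may be only part of what the source reports. "The series", "measured", "known", "first", "only" and "open" are said of these compounds alone.

Measured so far:
compound 1, `COc1cc(N)c(Cl)cc1NC(=O)C1CCN(CC2CCCCC2)CC1`: 2.9 mg/kg
compound 2, `COc1cc(N)c(Cl)cc1NC(=O)C1CCN(Cc2ccc(F)cc2)CC1`: 0.6 mg/kg

Two compounds have numbers in a functional assay on the whole organism for antagonist activity, with Mus musculus as the target; a lower number here means that less compound is needed, a higher number that more compound is needed for the effect. Compound 1 gives 2.9 mg/kg, the highest of the two; its nearest neighbour is compound 2, which gives 0.6 mg/kg. Going by the values given here, the only step between measured compounds is a 4.8-fold lower number from compound 1 to compound 2 (0.68 log units; beyond the scatter), a change on a saturated chain carbon bound to an amine nitrogen in a ring.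

Compound 3, `CCC(CC)CN1CCC(C(=O)Nc2cc(Cl)c(N)cc2OC)CC1`, is not yet measured. Relative to compound 1 it carries pentan-3-yl in place of cyclohexyl on a saturated chain carbon bound to an amine nitrogen in a ring. The new group is again saturated, so the step from compound 1 to compound 2, which put an aromatic ring in place of the saturated one, bears on it only loosely: it shows that the group at this position can move the number well beyond the scatter, but it says nothing about a branched chain standing in for the ring. Among the compounds with values here, with no closer precedent, the expectation for compound 3 is a step of about a 1.2-fold higher number from compound 1 to compound 3 (0.08 log units; within the scatter), within the usual scatter, in either direction. Compound 3 is therefore estimated at 3.5 mg/kg, with a range from 1.2 mg/kg to 10 mg/kg.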

Compound 3, dose for half-maximal effect: > 10 mg/kg
Compound 3: no number, only a limit; the forecaster's own chance of this, stated with the estimate: 5%; middle value at least 2.8-fold (0.45 log units) from the limit.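

In this assay compound 3 stands only as a limit of the assay, not as a number: the limit of > 10 mg/kg in this assay, at which 1 of the 3 values shown sits.

Even as a limit, this reading shows that the position responds to a change between two saturated groups, with cyclohexyl giving way to pentan-3-yl (an at least 3.4-fold higher number from compound 1 to compound 3 (0.53 log units; beyond the scatter)). The earlier step had shown a change of this kind only for an aromatic ring replacing a saturated one, and a similar carbon count with no hydrogen-bond donors or acceptors on either group did not keep the number in place. The span at this position also widens, with 4-fluorophenyl and pentan-3-yl now far apart (an at least 16-fold higher number from compound 2 to compound 3 (1.22 log units; beyond the scatter)), and among these three compounds the two groups carrying a ring give numbers while the open-chain group gives only a limit.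

With a single open-chain group in hand, the compounds shown cannot separate the loss of the ring from the branching of the chain; a straight pentyl chain and a cyclopentyl group would bear on that directly. As far as these compounds go, how far compound 3 lies beyond its limit also stays open, so the true size of both steps remains unknown.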